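The compounds below may be only part of what the source reports. "The series", "measured", "known", "first", "only" and "open" are said of these compounds alone.

Values in an ADME assay (liver, Mus musculus) for metabolic stability, read by LC-MS, using microsomes, tested at 1 uM (on this read-out lower numbers stand for a shorter-lived compound and higher numbers for a longer-lived compound), where the ">" entries are limits of the assay:
compound 1 `C/C(=N/c1ccnc2cc(Cl)ccc12)NCCCCN1CCCCC1`: > 1 h
compound 2 `C/C(=N/c1ccnc2cc(Cl)ccc12)NC1CCN(Cc2ccccc2)CC1`: > 1 h
compound 3 `CC(C)/C(=N/c1ccnc2cc(Cl)ccc12)NCCCCN1CCCCC1`: 0.517 h

Compound 2 stands at the limit of > 1 h in this assay, at which 2 of the 3 values shown sit, so its value is a limit and not a number. Compound 4 `C/C(=N/c1ccnc2cc(Cl)ccc12)NC1CCN(C(C)C)CC1` differs from compound 2 in isopropyl in place of benzyl on an amine nitrogen in a ring.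

Among the measured compounds shown here, the only measured step is an at least 1.9-fold lower number from compound 1 to compound 3 (0.28 log units; that floor lies within the scatter). It also brings in isopropyl, but on a carbon with a double bond to nitrogen, so it bears on this change only loosely. No step beyond the scatter is expected in this assay, and no direction can be given with confidence.

The expected change is a number no higher from compound 2 to compound 4 (the limit leaves the size open).

Compound 4 is estimated at 1 h, with an expected range of 0.5 h to 2 h.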

Compound 4, half-life: > 1 h
Compound 4 was reported as a limit; the forecaster's own chance of this, stated with the estimate: 55%; the middle value lies on the limit itself.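

Compound 2 and compound 4 are both reported as limits in this assay, so no step can be read between them: the limit of > 1 h in this assay, at which 3 of the 4 values shown sit.

The compounds shown leave open whether isopropyl in place of benzyl on an amine nitrogen in a ring changes the half-life at all, and by how much.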